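The source may hold more compounds than are shown below. What is called first, only, known or untested is meant among the compounds shown, and "the series" means these compounds.

In an in vitro ADME assay on microsomes from liver (Homo sapiens) for metabolic stability (on this read-out lower numbers stand for slow clearance and higher numbers for fast clearance), compound 1 `O=C(COCc1ccccc1)N1CCN(c2ccc(Cl)cc2)CC1` gives 290 mL.min-1.g-1 and compound 2 `O=C(COCc1ccccc1)N1CCN(c2ccc(F)cc2F)CC1` gives 580 mL.min-1.g-1, so these two values lie within the usual scatter of each other. Compound 3 `O=C(COCc1ccccc1)N1CCN(c2cc(Cl)ccn2)CC1` differs from compound 2 by one swap on an amine nitrogen in a ring: 4-chloropyridin-2-yl in place of 2,4-difluorophenyl on an amine nitrogen in a ring. Going by the values given here, the only measured step, a 2.0-fold higher number from compound 1 to compound 2 (0.30 log units; within the scatter), changes the same place and stays within the scatter, although neither measured compound has a hetero atom in that aromatic ring. A small, slightly downward change is therefore expected, estimated as a 1.9-fold lower number from compound 2 to compound 3 (0.29 log units; within the scatter). The estimate for compound 3 is 300 mL.min-1.g-1, with an expected range from 110 mL.min-1.g-1 to 700 mL.min-1.g-1.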

Compound 3, intrinsic clearance in microsomes: 130 mL.min-1.g-1
For compound 3 the middle estimate is 2.3-fold (0.36 log units) above the measured one, within the range that was stated.
By their numbers in this assay, from the lowest: compound 3; then compounds 1 and 2 (each within the scatter of the next).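

In this assay, a change at this place on the amine nitrogen now goes beyond the scatter: putting 4-chloropyridin-2-yl there gives a lower number than 2,4-difluorophenyl (a 4.5-fold lower number from compound 2 to compound 3 (0.65 log units; beyond the scatter)) and than 4-chlorophenyl (a 2.2-fold lower number from compound 1 to compound 3 (0.35 log units; beyond the scatter)). Both steps point the same way, so here the aromatic ring with a hetero atom gives slower clearance than either carbon-only ring. No measurement shown gives a reason for this difference. Still open, from the compounds shown here alone, is whether the same holds for a pyridine ring carrying a methoxy group or a nitrile in place of chlorine.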